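Methoxy to hydroxy on the shared core: cytotoxicity notes

The source may hold more compounds than are shown below. What is called first, only, known or untested is meant among the compounds shown, and "the series" means these compounds.

Measured so far:
compound 1 `COc1cc(C)cc(-c2nn(CC#N)cc2-c2ccnc(-c3ccc(N(C)C)cc3)c2)c1`: -41%
compound 2 `COc1cc(C)cc(-c2nn(CC#N)cc2-c2ccc(-c3cccc(C(C)=O)c3)nc2)c1`: 1%

In a functional assay on HCT-116 cells (Homo sapiens) for cytotoxicity, read by sulforhodamine B assay, with a stated time of 48 h, tested at 1 uM (on this read-out higher numbers stand for a weaker effect at the one concentration tested and lower numbers for a stronger effect), compound 1 gives -41%, the lower of the two numbers recorded, and compound 2 gives 1%; the gap between the two lies beyond the scatter, so compound 1 shows the stronger effect of the pair. Among the compounds with values here, no pair of measured compounds differing in a single place has been recorded, so no measured step can guide the next change.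

Compound 3 `Cc1cc(O)cc(-c2nn(CC#N)cc2-c2ccnc(-c3ccc(N(C)C)cc3)c2)c1` is still to be measured. It differs from compound 1 only in the way counted here: hydrogen in place of methyl on an oxygen on an aromatic ring

With nothing of this kind measured, the expectation is a step from compound 1 to compound 3 that is small, toward a weaker effect, and possibly inside the scatter; the expected step is a number 16 percentage points higher from compound 1 to compound 3 (beyond the scatter). For compound 3 the estimated value is -25%, with a range from -60% to 15%.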

Compound 3, a percentage reported as activity, at one concentration (the size of the read-out at that concentration, not a potency): 2%
Compound 3: the middle estimate sits 27 percentage points below what was measured; measured number inside the range.
By their numbers in this assay, from the lowest: compound 1; then compounds 2 and 3 (each within the scatter of the next).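

In this assay, within the data shown here, the change from methoxy to hydroxy gives a number 43 percentage points higher from compound 1 to compound 3 (beyond the scatter) and is the only single-place step so far. The methyl on this oxygen is therefore not a silent feature of compound 1: taking it off, with the rest of the structure unchanged, moves the read-out by a large amount toward a weaker effect. No measurement at hand explains the size of this step.

Going by these compounds, it remains open whether the effect needs a methyl in particular or would also hold with an ethyl, a difluoromethyl or a longer chain on this oxygen, or with an amine in place of the oxygen. Also open, on these data alone, is whether the same change on the core of compound 2 would give a step of similar size.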